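Swapping methoxy for chloro on the pendant phenyl ring

The compounds below may be only part of what the source reports. "The series", "measured", "known", "first", "only" and "open" are said of these compounds alone.

Compound 1 `COc1ccc(C2CC(c3ccccc3)=NN2C2=NC(=O)/C(=C3\C(=O)Nc4ccc(Br)cc43)S2)cc1`, compound 2 `COc1ccc(C2=NN(C3=NC(=O)/C(=C4\C(=O)Nc5ccc(Br)cc54)S3)C(c3ccc(OC)cc3)C2)cc1` and compound 3 `COc1ccc(C2=NN(C3=NC(=O)/C(=C4\C(=O)Nc5ccc(Cl)cc54)S3)C(c3ccc(OC)cc3)C2)cc1` share one core and were all tested in a functional assay on cells (Cancer cell lines, Homo sapiens) for cytotoxicity, read by sulforhodamine B assay, with a stated time of 48 h; a lower number here means a stronger inhibitor of growth, a higher number a weaker inhibitor of growth. In this assay compound 1 gives 240 nM, compound 2 gives 270 nM and compound 3 gives 250 nM. Compound 2 therefore sits within the usual scatter of both neighbours: the step of a 1.1-fold higher number from compound 1 to compound 2 (0.05 log units; within the scatter), which is methoxy in place of hydrogen on an aromatic carbon, and the step of a 1.1-fold lower number from compound 2 to compound 3 (0.03 log units; within the scatter), which is chloro in place of bromo on an aromatic carbon, both stay inside the scatter.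

Compound 4 `COc1ccc(C2=NN(C3=NC(=O)/C(=C4\C(=O)Nc5ccc(Br)cc54)S3)C(c3ccc(Cl)cc3)C2)cc1` has not yet been measured. It differs from compound 2 by chloro in place of methoxy on an aromatic carbon. Among the compounds with values here, no measured pair covers exactly this exchange. The closest guide is the step from compound 1 to compound 2, where adding a methoxy at the same position hardly moved the number, and the halogen swap between compound 2 and compound 3 was equally quiet. On that basis compound 4 is expected to show a step of a 1.0-fold lower number from compound 2 to compound 4 (0.02 log units; within the scatter) in this assay, no more than the scatter, in no firm direction. The estimate for compound 4 in this assay is 260 nM, with a range from 130 nM to 520 nM.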

Compound 4, concentration for 50% growth inhibition: 180 nM
Estimate against measurement, compound 4: 1.4-fold (0.16 log units) above, and the stated range covers the measured number.
By their numbers in this assay, from the lowest: compounds 4, 1, 3 and 2 (each within the scatter of the next).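

In this assay, the exchange of 4-methoxyphenyl to 4-chlorophenyl gives a 1.5-fold lower number from compound 2 to compound 4 (0.18 log units; within the scatter), so this place, on an aromatic carbon para to a large group, accepts either group with no change that can be told from the scatter. Within the data shown here, the earlier steps changed other places in the molecule, so this is the first sign that the methoxy here can be given up, with its oxygen and its one hydrogen-bond acceptor, and a single chlorine put in its place, while growth inhibition stays at the level of compound 2. No measurement shown here bears on the reason that these two groups read alike.

From the compounds shown here alone, the two groups compared at this place are both small and uncharged, so it remains open whether this tolerance would extend to an amine, a carboxylic acid or a longer chain such as butoxy. Plain hydrogen at this same place also remains untested among the compounds shown, so the data cannot tell whether any group is needed here at all.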